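This account rests on a few compounds, and the source may have more. Where it says the series, first, only, none or still open, it means among the compounds named here.

Measured compounds:
Compound 1 `CC(C)=CCC/C(C)=C/COc1cc(=O)n(CCCO)c2c1CC(CC=C(C)C)C(C)(C)C2` — 18.4%
Compound 2 `CC(C)=CCC/C(C)=C/CC1Cc2c(OCc3ccccc3)cc(=O)n(CCCO)c2CC1(C)C` — 1.5%
Compound 3 `CC(C)=CCC/C(C)=C/CC1Cc2c(OCC=C(C)C)cc(=O)n(CCCO)c2CC1(C)C` — 15.9%

In a functional assay on PANC-1 cells (Homo sapiens) for inhibition, read by MTT assay, with a stated time of 24 h, tested at 10 uM (on this read-out higher numbers stand for more inhibition at the one concentration tested (going by the name of the read-out) and lower numbers for less inhibition), compound 3 stands second highest of the three numbers. Its nearest neighbour is compound 1, whose value lies within the scatter of that of compound 3, while compound 2 lies furthest, beyond the scatter below it. Compound 4 `CC(C)=CCC/C(C)=C/COc1cc(=O)n(CCCO)c2c1CC(C/C=C(\C)CCC=C(C)C)C(C)(C)C2` is not yet measured. It differs from compound 3 by 3-methylbut-2-en-1-yl in place of hydrogen on a saturated chain carbon bound to a double-bonded chain carbon, which read one bond further out turns the (3-methylbut-2-en-1-yl)oxy group into a (3,7-dimethylocta-2,6-dien-1-yl)oxy group.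

Going by the values given here, only one measured step is known, a number 14.4 percentage points higher from compound 2 to compound 3 (beyond the scatter), and it concerns a different exchange on the same oxygen. It does not bear directly on the present change. Compound 1, however, already carries the (3,7-dimethylocta-2,6-dien-1-yl)oxy group that enters here, and its value sits within the scatter of that of compound 3, though compound 1 differs from compound 3 in a second place as well. On this basis no step beyond the scatter is expected for the step from compound 3 to compound 4 in this assay, that is a number 1.1 percentage points higher from compound 3 to compound 4 (within the scatter). Compound 4 is therefore estimated at 17%, with a range from 5% to 30%.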

Compound 4, a percentage reported as inhibition, at one concentration (the size of the read-out at that concentration, not a potency): 3.1%
The estimate for compound 4 lay 13.9 percentage points above the measured number, outside the stated range (below it).
By their numbers in this assay, from the lowest: compounds 2 and 4 (each within the scatter of the next); then compounds 3 and 1 (each within the scatter of the next).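

In this assay the addition of 3-methylbut-2-en-1-yl on a saturated chain carbon bound to a double-bonded chain carbon proves not to be neutral: it gives a number 12.8 percentage points lower from compound 3 to compound 4 (beyond the scatter) on the oxygen-bound chain and a number 15.3 percentage points lower from compound 1 to compound 4 (beyond the scatter) on the other chain. Among these compounds, then, the core with two 3,7-dimethylocta-2,6-dien-1-yl chains reads lower than either core with one such chain and one 3-methylbut-2-en-1-yl chain, which compound 1 and compound 3 alone could not show. Replacing phenyl with 2,6-dimethylhepta-1,5-dien-1-yl gives a number 1.6 percentage points higher from compound 2 to compound 4 (within the scatter), whereas 2-methylprop-1-en-1-yl in that place gave a number 14.4 percentage points higher from compound 2 to compound 3 (beyond the scatter) on the same oxygen-bound chain.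

Nothing given here accounts for the drop. As far as these compounds go, whether an amine or a carboxylic acid in place of the (3,7-dimethylocta-2,6-dien-1-yl)oxy group would change the number in this assay stays open.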